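The source may report more compounds than this note shows. Statements on the series, on what has been measured and on what is new or still open speak of the compounds shown alone.

Measured so far:
compound 1 `COc1cc(C(=O)n2ccc3ccccc32)cc(OC)c1OC`: 5200 nM
compound 2 `COc1cc(C(=O)c2ccc3[nH]ccc3c2)cc(OC)c1OC`: 88 nM

In a functional assay on MKN-45 cells (Homo sapiens) for inhibition, with a stated time of 72 h (a lower number here means a stronger inhibitor, a higher number a weaker inhibitor), compound 1 gives 5200 nM, while compound 2 gives 88 nM. This is the lower of the two numbers, and the gap lies well beyond the usual scatter of repeated measurements. Compound 2 is therefore the stronger inhibitor of this pair.

Compound 3 `COc1cc(C(=O)c2ccc3c(ccn3CO)c2)cc(OC)c1OC` differs from compound 2 in one place: hydroxymethyl in place of hydrogen on an aromatic nitrogen. In words, it carries hydroxymethyl in place of hydrogen on an aromatic nitrogen. Going by the values given here, no measured pair shows this change, so the expectation is uncertain. A small rise in the number in this assay is expected, close to the edge of the scatter, meaning a slightly weaker inhibitor. The expected size of the change is a 2.3-fold higher number from compound 2 to compound 3 (0.36 log units; beyond the scatter). The estimate for compound 3 is 200 nM, with an expected range of 50 nM to 900 nM.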

Compound 3, half-maximal inhibitory concentration: 33 nM
Compound 3: middle estimate off by 6.1-fold (0.78 log units), on the high side, and the stated range ends above it.
By their numbers in this assay, from the lowest: compound 3; then compound 2; then compound 1.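

The aromatic nitrogen of compound 2 does not have to keep its hydrogen. In this assay putting hydroxymethyl in its place gives a 2.7-fold lower number from compound 2 to compound 3 (0.43 log units; beyond the scatter) and so a modestly stronger inhibitor, a step that lies beyond the scatter. This position therefore tolerates a group of 2 heavy atoms with a hydrogen-bond donor and acceptor, and the number falls rather than rises. Nothing measured here accounts for the direction of this step.

The compounds shown leave open whether the gain depends on the hydroxyl oxygen or would come with any small group on this nitrogen, a question that a plain methyl group could help to settle. They also leave open how much room this position offers, which a longer chain such as hydroxyethyl, or an amine such as aminomethyl, would begin to test.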